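The source may report more compounds than this note shows. Statements on the series, on what has been measured and on what is new or still open speak of the compounds shown alone.

Measured compounds:
compound 1, `Oc1cccc(-c2cc(-c3ccco3)cc(-c3ccccc3O)n2)c1`, 1790 nM
compound 2, `Oc1ccccc1-c1cc(-c2ccccn2)cc(-c2ccccc2O)n1`, > 50000 nM

Compound 1 `Oc1cccc(-c2cc(-c3ccco3)cc(-c3ccccc3O)n2)c1` carries a 3-hydroxyphenyl group, a furan-2-yl group and a 2-hydroxyphenyl group on its shared core. In a functional assay on DU-145 cells (Homo sapiens) for cytotoxicity, read by CCK-8 assay (on this read-out lower numbers stand for stronger inhibition and higher numbers for weaker inhibition), compound 1 gives 1790 nM. Compound 2 `Oc1ccccc1-c1cc(-c2ccccn2)cc(-c2ccccc2O)n1` carries two 2-hydroxyphenyl groups and a pyridin-2-yl group on the same core. In this assay compound 2 reaches only a limit, > 50000 nM, so no number is known for it; this is the limit of > 50000 nM in this assay, at which 1 of the 2 values shown sits. Compound 3 `Oc1cccc(-c2cc(-c3ccccn3)cc(-c3ccccc3O)n2)c1` has not been measured. It differs from compound 2 by 3-hydroxyphenyl in place of 2-hydroxyphenyl on an aromatic carbon. Going by the values given here, no measured pair shows this change, so its effect must be judged from compound 1 and compound 2 alone. For compound 3 a step toward stronger inhibition is expected, an at least 3.3-fold lower number from compound 2 to compound 3 (0.52 log units; beyond the scatter), with a value estimated at 15000 nM, between 3000 nM and 60000 nM.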

Compound 3, half-maximal inhibitory concentration: 17100 nM
Estimate against measurement, compound 3: 1.1-fold (0.06 log units) below; measured number inside the range.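

In this assay, 3-hydroxyphenyl in place of 2-hydroxyphenyl on the aromatic carbon next to the ring nitrogen gives an at least 2.9-fold lower number from compound 2 to compound 3 (0.46 log units; beyond the scatter), showing that this position responds to a change between two groups made of the same atoms. Going by these compounds alone, the reading for compound 2 is a limit and not a number, so this step has no exact size: the limit of > 50000 nM in this assay, at which 1 of the 3 values shown sits. With 3-hydroxyphenyl held in place, pyridin-2-yl in place of furan-2-yl gives a 9.6-fold higher number from compound 1 to compound 3 (0.98 log units; beyond the scatter), the first comparison to isolate that other group.

Going by these compounds, it remains open whether the 3-hydroxyphenyl step would hold with furan-2-yl on the shared core. Also open, on these data alone, is how a plain phenyl group or a methoxy group in place of the hydroxyl would read at this position, and how a thiophene would compare with furan-2-yl.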